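Amide N-demethylation on the shared core: solubility outlook

The source may hold more compounds than are shown below. What is called first, only, known or untested is meant among the compounds shown, and "the series" means these compounds.

Measured compounds, with their readings in a physicochemical assay for solubility, read by nephelometry, measured as kinetic solubility, at pH 2; on this read-out higher numbers stand for higher solubility and lower numbers for lower solubility:
- compound 1, `COc1ccc(-c2cc(-c3ccc(NS(C)(=O)=O)cc3)cnc2N)cn1`, gives > 100 ug/mL, a limit of the assay.
- compound 2, `COc1ccc(-c2cc(-c3ccc(C(F)(F)F)cc3)cnc2N)cn1`, gives > 100 ug/mL, a limit of the assay.
- compound 3, `COc1ccc(-c2cc(-c3ccc(C(=O)N(C)C)cc3)cnc2N)cn1`, gives > 100 ug/mL, a limit of the assay.

Compound 3 stands at the upper limit of this assay, as do the other two measured compounds; no number separates them, only (the limit of > 100 ug/mL in this assay, at which 3 of the 3 values shown sit).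

Compound 4, `CNC(=O)c1ccc(-c2cnc(N)c(-c3ccc(OC)nc3)c2)cc1`, differs from compound 3 by hydrogen in place of methyl on an amide-type nitrogen.

Within the data shown here, none of the measured steps touches the amide nitrogen, and all three steps between the measured compounds sit between two limits: a step that the two limits leave unreadable from compound 1 to compound 2, a step that the two limits leave unreadable from compound 1 to compound 3 and a step that the two limits leave unreadable from compound 2 to compound 3 are unreadable in size. So no measured step bears directly on the change to compound 4, and the shared core and substituent pattern across compounds 1, 2 and 3 have so far given nothing below the limit.

On that basis compound 4 is expected to remain near or at the same limit in this assay, with the step from compound 3 estimated as a step that the limit leaves unreadable from compound 3 to compound 4, that is, none beyond the scatter. Compound 4 is estimated at 150 ug/mL, with a range from 70 ug/mL to 300 ug/mL.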

Compound 4, solubility: 50 ug/mL
For compound 4 the middle estimate is 3.0-fold (0.48 log units) above the measured one; measured number below the stated range.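

In this assay compound 4 is the only compound shown with a reading that is a number rather than a limit, while the others sit at a limit: the limit of > 100 ug/mL in this assay, at which 3 of the 4 values shown sit.

On the amide-type nitrogen, hydrogen in place of methyl gives an at least 2.0-fold lower number from compound 3 to compound 4 (0.30 log units; that floor lies within the scatter), and the changes on the aromatic carbon give an at least 2.0-fold lower number from compound 2 to compound 4 (0.30 log units; that floor lies within the scatter) and an at least 2.0-fold lower number from compound 1 to compound 4 (0.30 log units; that floor lies within the scatter). Each of these is only a floor, so the shared core is not pinned at the limit, but the true size of each step remains unreadable.

On these data alone, the steps among compound 1, compound 2 and compound 3 cannot be read, so their order in this assay stays open. Also open, as far as these compounds go, is whether an unsubstituted carboxamide, a carboxylic acid or an amine at this place would read as a number or return to the limit.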